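The source may hold more compounds than are shown below. What is called first, only, known or untested is meant among the compounds shown, and "the series" means these compounds.

Compound 2, whose structure is `COc1cc(-c2cc(C(=O)/C=C/c3ccccc3)nc3cc(-c4ccccc4)nn23)cc(OC)c1OC`, was tested in an ADME assay on HEK293 cells (Homo sapiens) for antiproliferative activity, read by MTT assay, with a stated time of 24 h (on this read-out higher numbers stand for weaker inhibition and lower numbers for stronger inhibition), and gave 44800 nM. Among the three numbers measured, compound 2 stands second highest: its closest neighbour is compound 3 `COc1ccc(/C=C/C(=O)c2cc(-c3cc(OC)c(OC)c(OC)c3)n3nc(-c4ccccc4)cc3n2)cc1OC`, which in this assay gave 41000 nM, and the compound furthest from it is compound 1 `COc1cc(-c2cc(C(=O)/C=C/c3ccc(Cl)cc3)nc3cc(-c4ccccc4)nn23)cc(OC)c1OC`, which gave 53900 nM. The separations are small: a 1.1-fold lower number from compound 2 to compound 3 (0.04 log units; within the scatter), a 1.2-fold lower number from compound 1 to compound 2 (0.08 log units; within the scatter) and a 1.3-fold lower number from compound 1 to compound 3 (0.12 log units; within the scatter) are all within the scatter.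

Compound 4 `COc1cc(-c2cc(/C=C/C(=O)c3ccc(C)c(C)c3)nc3cc(-c4ccccc4)nn23)cc(OC)c1OC` differs from compound 2 in one place: 2-((3,4-dimethylphenyl)carbonyl)ethenyl in place of (2-phenylethenyl)carbonyl on an aromatic carbon. The measured steps that bear on this are those exchanging the aryl ring at the end of the same chain, that is the step from compound 2 to compound 3 and the step from compound 1 to compound 2, and both stayed within the scatter. Among the measured compounds shown here, no measured step examines the turned-round arrangement of carbonyl and ethenyl that enters here, so nothing beyond the scatter is expected in this assay. The expected step from compound 2 to compound 4 is therefore a 1.0-fold higher number from compound 2 to compound 4 (0.00 log units; within the scatter), and compound 4 is estimated at 45000 nM, with a range from 20000 nM to 100000 nM.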

Compound 4, half-maximal inhibitory concentration: 72500 nM
For compound 4 the middle estimate is 1.6-fold (0.21 log units) below the measured one; the range from low to high includes it.
By their numbers in this assay, from the lowest: compounds 3, 2, 1 and 4 (each within the scatter of the next).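

In this assay the reversed chain on this aromatic carbon, next to the ring nitrogen, gives a 1.6-fold higher number from compound 2 to compound 4 (0.21 log units; within the scatter) and a 1.3-fold higher number from compound 1 to compound 4 (0.13 log units; within the scatter) with neither step beyond the scatter. The earlier compounds shown here varied only the aryl ring at the end of a chain joined to the core through its carbonyl, whereas compound 4 shows that this position also tolerates 2-((3,4-dimethylphenyl)carbonyl)ethenyl, joined through its ethenyl end, without a step beyond the scatter. No available evidence bears on this result.

Because compound 4 turns the chain round and carries the 3,4-dimethylphenyl ring at once, the compounds shown do not separate these two changes. From the compounds shown here alone, what an amine or a carboxylic acid on this aromatic carbon, in place of the whole chain, would give remains open.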